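Bromo for Chloro: A Small Step Expected From Close Analogues

A few compounds are considered here, and "the series" means these few. Any claim that something is new, unique, unknown or untested is made for them only; others in the source may bear on it.

Compound 1 `CC1(C)CCC(C)(C)c2cc(C(=O)/C=C/c3c[nH]c4ccccc34)ccc21`; in a functional assay on Huh-7 cells (Homo sapiens) for cytotoxicity, read by sulforhodamine B assay, with a stated time of 3 days (a lower number here means a stronger inhibitor, a higher number a weaker inhibitor), compound 1 gives < 10 nM, a limit of the assay.
Compound 2 `COc1ccc2[nH]cc(/C=C/C(=O)c3ccc4c(c3)C(C)(C)CCC4(C)C)c2c1`; in this assay compound 2 gives 15500 nM.
Compound 3 `CC1(C)CCC(C)(C)c2cc(C(=O)/C=C/c3c[nH]c4ccc(Cl)cc34)ccc21`; in this assay compound 3 gives 15400 nM.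

Of the two numbers shown in this assay, compound 3 holds the lower one, but a 1.0-fold lower number from compound 2 to compound 3 (0.00 log units; within the scatter), so the two stand together. Compound 1 sits at the limit of < 10 nM in this assay, at which 1 of the 3 values shown sits.

Compound 4 `CC1(C)CCC(C)(C)c2cc(C(=O)/C=C/c3c[nH]c4ccc(Br)cc34)ccc21` differs from compound 3 by bromo in place of chloro on an aromatic carbon. Going by the values given here, two measured steps bear on this change: an at least 1500-fold higher number from compound 1 to compound 3 (3.18 log units; beyond the scatter), and a 1.0-fold lower number from compound 2 to compound 3 (0.00 log units; within the scatter). The large step belongs to adding a substituent at that aromatic carbon; the swap between two substituents there left the number unchanged. For compound 4 the expected outcome is therefore a 1.0-fold lower number from compound 3 to compound 4 (0.01 log units; within the scatter). Compound 4 is estimated at 15000 nM, within 5000 nM to 45000 nM.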

Compound 4, half-maximal inhibitory concentration: 14000 nM
The estimate for compound 4 lay 1.1-fold (0.03 log units) above the measured number, and the stated range covers the measured number.
By their numbers in this assay, from the lowest: compounds 4, 3 and 2 (each within the scatter of the next). At a limit, below all of these: compound 1.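

The swap of bromo for chloro gives a 1.1-fold lower number from compound 3 to compound 4 (0.04 log units; within the scatter) and the exchange of methoxy for bromo gives a 1.1-fold lower number from compound 2 to compound 4 (0.04 log units; within the scatter), so three different substituents at this aromatic carbon now stand together. Bromo in place of hydrogen gives an at least 1400-fold higher number from compound 1 to compound 4 (3.14 log units; beyond the scatter), so the third substituent also shows the large step seen with the other two. The value of compound 1 is a limit, not a number: the limit of < 10 nM in this assay, at which 1 of the 4 values shown sits.

From the compounds shown here alone, whether fluoro or an amine at this carbon would stand with compound 1 or with compounds 2, 3 and 4 stays open. So does whether these groups would give the same step elsewhere on the shared core.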